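From hydroxy to methoxy in compound 1

The source may hold more compounds than are shown below. What is called first, only, known or untested is meant among the compounds shown, and "the series" means these compounds.

In a functional assay on SN12C cells (Homo sapiens) for antiproliferative activity, read by sulforhodamine B assay, with a stated time of 48 h (on this read-out lower numbers stand for stronger inhibition of growth and higher numbers for weaker inhibition of growth), compound 1 (`O=C(NCCCNc1cc(-c2cn(-c3ccccc3)nc2-c2cccc(O)c2)ccn1)Nc1ccc(F)cc1`) gives 8370 nM. Compound 2 (`O=C(NCCCNc1cc(-c2cn(-c3ccccc3)nc2-c2cccc(O)c2)ccn1)Nc1cccc(C(F)(F)F)c1`) gives 7910 nM, so the two values lie within the scatter of each other and neither stands apart. Compound 3 (`COc1cccc(-c2nn(-c3ccccc3)cc2-c2ccnc(NCCCNC(=O)Nc3ccc(F)cc3)c2)c1`) is still unmeasured. It differs from compound 1 by methyl in place of hydrogen on an oxygen on an aromatic ring, with methyl in place of hydrogen on an oxygen on an aromatic ring, so 3-hydroxyphenyl becomes 3-methoxyphenyl. Within the data shown here, the only measured step, a 1.1-fold lower number from compound 1 to compound 2 (0.02 log units; within the scatter), is small, but it lies at another place, on an amide-type nitrogen, and bears only indirectly on this change. Among the measured compounds shown here, no measured pair tests this oxygen, so no step beyond the scatter is expected in this assay, though the uncertainty is wide. The estimated step is a 1.1-fold higher number from compound 1 to compound 3 (0.03 log units; within the scatter). Compound 3 is expected at 9000 nM, with an estimated range of 4500 nM to 20000 nM.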

Compound 3, concentration for total growth inhibition: > 37000 nM
Compound 3 gave a limit, no number; the forecaster's own chance of this, stated with the estimate: 10%; at least 4.1-fold (0.61 log units) between middle value and limit.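

Compound 3 gives > 37000 nM in this assay, which is a limit and not a number. Methyl in place of hydrogen on this oxygen, turning 3-hydroxyphenyl into 3-methoxyphenyl, gives an at least 4.4-fold higher number from compound 1 to compound 3 (0.64 log units; beyond the scatter), so growth inhibition responds to a change at this oxygen, whereas the only earlier step, on an amide-type nitrogen, was a 1.1-fold lower number from compound 1 to compound 2 (0.02 log units; within the scatter). The full size of the new step cannot be read, because compound 3 stands at a limit: the limit of > 37000 nM in this assay, at which 1 of the 3 values shown sits.

The compounds shown do not separate the loss of the hydroxy hydrogen from the arrival of the methyl, and they do not tell how an amino group or an ethoxy group at this place would read. They also leave open whether 3-methoxyphenyl gives the same step alongside 3-(trifluoromethyl)phenyl on the amide-type nitrogen.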